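A few compounds are considered here, and "the series" means these few. Any claim that something is new, unique, unknown or untested is made for them only; others in the source may bear on it.

Two compounds of this series have a number in a physicochemical assay for lipophilicity; a higher number here means a more lipophilic compound, a lower number a more polar compound. Compound 1 `COC(=O)CNC(=O)C(CSc1ccc([N+](=O)[O-])cc1[N+](=O)[O-])NC(=O)CCC(NC(=O)OCc1ccccc1)C(=O)O` gives 1.32 there. Compound 2 `CC(C)OC(=O)CNC(=O)C(CSc1ccc([N+](=O)[O-])cc1[N+](=O)[O-])NC(=O)CCC(NC(=O)OCc1ccccc1)C(=O)O` gives 2.23 in this assay and so stands highest of the two numbers, with compound 1 as its nearest neighbour. Among the measured compounds shown here, the only measured step that bears on the next change is a number 0.91 log units higher from compound 1 to compound 2 (beyond the scatter). Compound 3 `CCC(C)OC(=O)CNC(=O)C(CSc1ccc([N+](=O)[O-])cc1[N+](=O)[O-])NC(=O)CCC(NC(=O)OCc1ccccc1)C(=O)O` differs from compound 2 by methyl in place of hydrogen on a saturated chain carbon, two bonds along the chain from an oxygen next to a carbonyl group. A smaller rise is expected here, a number 0.47 log units higher from compound 2 to compound 3 (beyond the scatter), because a number 0.91 log units higher from compound 1 to compound 2 (beyond the scatter) covered the change from methyl to isopropyl while now isopropyl goes to sec-butyl. For compound 3 the estimate in this assay is 2.7, within 2.3 to 3.1.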

Compound 3, partition coefficient: 2.72
Beside the measured number, compound 3's estimate is 0.02 log units below it; the range from low to high includes it.
By their numbers in this assay, from the lowest: compound 1; then compound 2; then compound 3.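

Isopropyl to sec-butyl still moves the number in this assay (a number 0.49 log units higher from compound 2 to compound 3 (beyond the scatter)), so the rise at this position does not stop at isopropyl. Over the whole series of groups on this oxygen the change reads a number 1.40 log units higher from compound 1 to compound 3 (beyond the scatter) and the numbers run in the order methyl, isopropyl, sec-butyl, with no compound shown going against that order. Nothing measured here accounts for the rise. Going by these compounds, whether a longer chain or a benzyl group on the same oxygen would continue the rise stays open. So does the effect of a branched tert-butyl group there.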